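The source may report more compounds than this note shows. Statements on the series, on what has been measured and on what is new or still open speak of the compounds shown alone.

Values in an ADME assay (liver) for metabolic stability, with Liver microsome (Homo sapiens) as the target, using microsomes and NADPH, with a stated time of 30 min, tested at 1 uM (a higher number here means faster removal of the compound, a lower number slower removal), are as follows.

Compound 1 `Cn1cc(-c2cc(C(O)(C(F)(F)F)C(F)(F)F)cnc2N2CCN(S(=O)(=O)c3ccc(N)nc3)CC2)cn1` gives 19 mL.min-1.g-1
Compound 2 `Nc1ccc(S(=O)(=O)N2CCN(c3ncc(C(O)(C(F)(F)F)C(F)(F)F)cc3-c3cccc(F)c3)CC2)cn1` gives 25 mL.min-1.g-1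
Compound 3 `CS(=O)(=O)c1ccc(-c2cc(C(O)(C(F)(F)F)C(F)(F)F)cnc2N2CCN(S(=O)(=O)c3ccc(N)nc3)CC2)cc1` gives 32 mL.min-1.g-1

In this assay, compound 3 at 32 mL.min-1.g-1 lies within the scatter of both other compounds. Compound 4 `Nc1ccc(S(=O)(=O)N2CCN(c3ncc(C(O)(C(F)(F)F)C(F)(F)F)cc3-c3ccncc3)CC2)cn1` carries pyridin-4-yl in place of 4-(methylsulfonyl)phenyl on an aromatic carbon. Three measured exchanges on this same aromatic carbon bear on the change: a 1.3-fold higher number from compound 1 to compound 2 (0.12 log units; within the scatter), a 1.7-fold higher number from compound 1 to compound 3 (0.23 log units; within the scatter) and a 1.3-fold higher number from compound 2 to compound 3 (0.11 log units; within the scatter). All three stayed within the scatter, although pyridin-4-yl itself has not been measured in this series. No shift beyond the scatter is therefore expected in either direction. The estimated step is a 1.3-fold lower number from compound 3 to compound 4 (0.11 log units; within the scatter). For compound 4, the expected value is 25 mL.min-1.g-1, with an estimated range from 12 mL.min-1.g-1 to 48 mL.min-1.g-1.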

Compound 4, intrinsic clearance in microsomes: 15 mL.min-1.g-1
For compound 4 the middle estimate is 1.7-fold (0.22 log units) above the measured one; the range from low to high includes it.
By their numbers in this assay, from the lowest: compounds 4, 1, 2 and 3 (each within the scatter of the next, the first and the last beyond it).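

In this assay, the exchange of 4-(methylsulfonyl)phenyl for pyridin-4-yl is the only one at this aromatic carbon to pass the scatter (a 2.1-fold lower number from compound 3 to compound 4 (0.33 log units; beyond the scatter)), while the other two exchanges to pyridin-4-yl stay within it (a 1.7-fold lower number from compound 2 to compound 4 (0.22 log units; within the scatter); a 1.3-fold lower number from compound 1 to compound 4 (0.10 log units; within the scatter)). This position therefore separates compound 3 and compound 4, but only modestly. Nothing available explains this step.

Going by these compounds, whether a carboxylic acid or an aminomethyl group on this carbon would give a lower number remains open. So does whether the step survives when the 2,2,2-trifluoro-1-hydroxy-1-(trifluoromethyl)ethyl group is replaced by a nitrile.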